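Swapping the para substituent on the thioether phenyl ring

The compounds below may be only part of what the source reports. "The series", "measured", "known", "first", "only" and "open" are said of these compounds alone.

Two thioether nucleosides sharing one core have been measured. Compound 1 `OC[C@H]1O[C@@H](n2cnc3c(CSc4ccccc4I)ncnc32)[C@H](O)[C@@H]1O` gives 282 nM in an assay on isolated protein for binding affinity to Equilibrative nucleoside transporter 1 (Homo sapiens); on this read-out lower numbers stand for stronger inhibition and higher numbers for weaker inhibition. Among the compounds with values here, compound 2 `COC(=O)c1ccc(SCc2ncnc3c2ncn3[C@@H]2O[C@H](CO)[C@@H](O)[C@H]2O)cc1` gives 813 nM in this assay, the higher of the two numbers; the only measured step, a 2.9-fold higher number from compound 1 to compound 2 (0.46 log units; beyond the scatter), exchanges both the group and its position on the phenyl ring. Compound 3 `CC(C)(C)c1ccc(SCc2ncnc3c2ncn3[C@@H]2O[C@H](CO)[C@@H](O)[C@H]2O)cc1` has not yet been measured. It differs from compound 2 by tert-butyl in place of methoxycarbonyl on an aromatic carbon. Within the data shown here, no measured step shares this change, since the one recorded step alters the ring substitution pattern as well as the substituent, so it bears only loosely on the move from compound 2 to compound 3. Compound 3 is therefore expected to land near compound 2, with at most a modest shift, and its number is estimated at 500 nM within 150 nM to 1700 nM. The expected step is a 1.6-fold lower number from compound 2 to compound 3 (0.21 log units; within the scatter).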

Compound 3, half-maximal inhibitory concentration: 331000 nM
Estimate against measurement, compound 3: 660-fold (2.82 log units) below; the whole stated range lies below it.
By their numbers in this assay, from the lowest: compound 1; then compound 2; then compound 3.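

In this assay, this place on the aromatic ring proves far less tolerant than the earlier step suggested: with tert-butyl in place of methoxycarbonyl, the result is a 410-fold higher number from compound 2 to compound 3 (2.61 log units; beyond the scatter), although the two groups have the same count of heavy atoms. Measured against the 2-iodophenyl group, the 4-(tert-butyl)phenyl group gives a 1200-fold higher number from compound 1 to compound 3 (3.07 log units; beyond the scatter), making compound 3 the weakest of the three by a wide margin. No evidence in hand accounts for this sharp loss.

From the compounds shown here alone, whether a methyl group, an amine or a carboxylic acid at this place would stay close to compound 2 or fall towards compound 3 remains open. So does whether a 4-iodophenyl group would match compound 1.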